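The source may hold more compounds than are shown below. What is called first, only, known or untested is meant among the compounds shown, and "the series" means these compounds.

Compound 1 `CO[C@]1(C)/C=C/C(=O)/C(CO)=C\C[C@](C)(CCC=C(C)C)/C=C/[C@H]1OC(=O)C=C(C)C`: 14300 nM
Compound 2 `CCN(CC)C/C1=C/C[C@](C)(CCC=C(C)C)/C=C/[C@@H](OC(=O)C=C(C)C)[C@](C)(O)/C=C/C1=O`: 130 nM

In a functional assay on MCF7 cells (Homo sapiens) for antiproliferative activity, read by MTT assay, with a stated time of 48 h (on this read-out lower numbers stand for stronger inhibition and higher numbers for weaker inhibition), compound 2 gives 130 nM, the lowest of the two numbers available here. The nearest measured compound is compound 1, which in this assay gives 14300 nM, a far higher number that lies well beyond the usual scatter. For the measured compounds named here, the two compounds differ in more than one place, so no single step between measured compounds is recorded, and nothing measured here shows how the group that changes below behaves.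

Compound 3 `CSC(=S)OC/C1=C/C[C@](C)(CCC=C(C)C)/C=C/[C@@H](OC(=O)C=C(C)C)[C@](C)(O)/C=C/C1=O` is the compound now to be measured. Compared with compound 2 it carries a group of 5 heavy atoms (2 carbon, 1 oxygen, 2 sulfur; no ring) in place of a group of 5 heavy atoms (4 carbon, 1 nitrogen; no ring), on a saturated chain carbon bound to a double-bonded ring carbon. Going by the values given here, the diethylamino group is thus replaced by a group built from carbon, oxygen and sulfur, and no measured pair shows what such an exchange does in this assay.

Without a comparable step, the expectation is a moderate rise in the number, meaning somewhat weaker inhibition, with a wide range to reflect the uncertainty. For compound 3 the estimate in this assay is 800 nM, between 150 nM and 5000 nM. This estimate corresponds to the expected step of a 6.2-fold higher number from compound 2 to compound 3 (0.79 log units; beyond the scatter).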

Compound 3, half-maximal inhibitory concentration: 900 nM
The estimate for compound 3 lay 1.1-fold (0.05 log units) below the measured number, within the range that was stated.
By their numbers in this assay, from the lowest: compound 2; then compound 3; then compound 1.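

In this assay, replacing diethylamino with the group of 2 carbon, 1 oxygen and 2 sulfur atoms gives a 6.9-fold higher number from compound 2 to compound 3 (0.84 log units; beyond the scatter), so the group on this saturated chain carbon bound to a double-bonded ring carbon affects the antiproliferative read-out. Both groups have 5 heavy atoms, no ring and no net charge, so heavy-atom count alone does not set the number; the entering group does differ in having 3 hydrogen-bond acceptors rather than 1 and a double bond outside aromatic rings. No measurement here explains the weaker inhibition of compound 3.

The pair cannot separate the loss of the nitrogen from the gain of the sulfur atoms, since one exchange brings both changes together. A dimethylamino group, a piperidine ring or a simple methyl ether at this place would be needed to show whether the nitrogen, the size of the amine or the sulfur-containing group accounts for the difference.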